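Methoxy in place of trifluoromethyl on compound 1

This account rests on a few compounds, and the source may have more. Where it says the series, first, only, none or still open, it means among the compounds named here.

Compound 1 `Cc1cc(O)c(C(=O)/C=C/c2ccc(C(F)(F)F)cc2)c(=O)o1` is the starting point for this step. In an ADME assay on HEK293 cells (Homo sapiens) for cytotoxicity, read by MTT assay (on this read-out higher numbers stand for weaker inhibition and lower numbers for stronger inhibition), compound 1 gives 100000 nM. Compound 2 `COc1cc(OC)c(OC)cc1/C=C/C(=O)c1c(O)cc(C)oc1=O` gives 100000 nM, and compound 3 `Cc1cc(O)c(C(=O)/C=C/c2cc(Br)cs2)c(=O)o1` gives 100000 nM. Compound 1 therefore stands level with both others, and the three measured compounds show no spread on this read-out. Among the compounds with values here, no pair among them differs in one place only, so the data contain no single-change step to use as a guide.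

Compound 4 `COc1ccc(/C=C/C(=O)c2c(O)cc(C)oc2=O)cc1` has not yet been measured. It differs from compound 1 on an aromatic carbon of a six-membered aromatic ring of carbon only, para to a large group, with methoxy in place of trifluoromethyl on an aromatic carbon.

In this assay, no step beyond the scatter is expected, in either direction. This expectation rests on compound 2, which also carries methoxy and gives 100000 nM. Within the data shown here, the data include no compound that isolates a single methoxy group, so the support is indirect. The estimated step of no change at the digits printed from compound 1 to compound 4 (within the scatter) is accordingly small. For compound 4 the estimated value is 100000 nM, with an expected range of 50000 nM to 200000 nM.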

Compound 4, half-maximal inhibitory concentration: 100000 nM
Compound 4: the middle estimate sits on the measured number at the digits printed; the measured number falls inside the stated range.
By their numbers in this assay, from the lowest: compounds 1, 2, 3 and 4 (each within the scatter of the next).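

In this assay, the series now has its first single-change step: methoxy in place of trifluoromethyl on an aromatic carbon, para to a large group, gives no change at the digits printed from compound 1 to compound 4 (within the scatter). This replaces the indirect support from compound 2 with a direct comparison at this position, where the group that leaves has 4 heavy atoms and no hydrogen-bond acceptor, and the group that enters has 2 heavy atoms and 1 hydrogen-bond acceptor. Across that difference in counted atoms and acceptors, the read-out shows no separation between the two compounds, and no measured evidence bears on the reason for this result.

On these data alone, it remains open whether an amine, a carboxylic acid or a longer chain at this same place would stay level with compound 1 at 100000 nM or would bring the first separation. Also open, as far as these compounds go, is whether methoxy in place of trifluoromethyl would give the same outcome on another aromatic carbon, since this single pair speaks for one position only.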